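Replacing the Amine Chain of Compound 3 with a Difluoropiperidine

A few compounds are considered here, and "the series" means these few. Any claim that something is new, unique, unknown or untested is made for them only; others in the source may bear on it.

In a functional assay on A-431 cells (Homo sapiens) for antiproliferative activity, read by sulforhodamine B assay, with a stated time of 72 h (on this read-out lower numbers stand for stronger inhibition and higher numbers for weaker inhibition), compound 3 (`CN(C)CCCNC(=O)Nc1cc2c(Nc3ccc(F)c(Cl)c3)ncnc2cc1O[C@H]1CCOC1`) gives 226 nM and stands level with compound 2 (`O=C(NCCN1CCCC1)Nc1cc2c(Nc3ccc(F)c(Cl)c3)ncnc2cc1O[C@H]1CCOC1`), which gives 247 nM and lies within the scatter of it. Compound 1 (`CS(=O)(=O)CCNC(=O)Nc1cc2c(Nc3ccc(F)c(Cl)c3)ncnc2cc1O[C@H]1CCOC1`) stands apart at 1570 nM on the same measure. Compound 4 (`O=C(Nc1cc2c(Nc3ccc(F)c(Cl)c3)ncnc2cc1O[C@H]1CCOC1)N1CCC(F)(F)CC1`) keeps the shared core but carries 4,4-difluoropiperidin-1-yl in place of (3-(dimethylamino)propyl)amino on a carbonyl carbon, so the dimethylamino group leaves.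

The steps of a 6.4-fold lower number from compound 1 to compound 2 (0.80 log units; beyond the scatter) and a 6.9-fold lower number from compound 1 to compound 3 (0.84 log units; beyond the scatter) both replace methylsulfonyl with a group holding an amine, and both are modest. The step of a 1.1-fold lower number from compound 2 to compound 3 (0.04 log units; within the scatter) shows no change beyond the scatter between the two amines. Among the measured compounds shown here, no measured step brings a ring onto the carbonyl carbon, so the evidence is indirect. Read in reverse, these steps suggest a modest move toward a higher number in this assay once the amine is gone. The estimated move is a 4.4-fold higher number from compound 3 to compound 4 (0.65 log units; beyond the scatter) and carries wide uncertainty. Compound 4 is estimated at 1000 nM with an expected range of 280 nM to 3600 nM as its span.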

Compound 4, half-maximal inhibitory concentration: 1860 nM
Compound 4: the middle estimate sits 1.9-fold (0.27 log units) below what was measured; the range from low to high includes it.
By their numbers in this assay, from the lowest: compounds 3 and 2 (each within the scatter of the next); then compounds 1 and 4 (each within the scatter of the next).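

In this assay, placing 4,4-difluoropiperidin-1-yl on the carbonyl carbon gives an 8.2-fold higher number from compound 3 to compound 4 (0.92 log units; beyond the scatter) and a 7.5-fold higher number from compound 2 to compound 4 (0.88 log units; beyond the scatter), so the amine-bearing chains of both compounds outperform this ring. Against the methylsulfonyl chain the same replacement gives a 1.2-fold higher number from compound 1 to compound 4 (0.07 log units; within the scatter), which places two quite different groups lacking the dimethylamino and pyrrolidin-1-yl groups at one level. No measurement shown accounts for this shift.

The compounds shown leave open whether the higher number follows the loss of the amine, the ring on the carbonyl carbon or its two fluorines. A plain piperidin-1-yl on the same carbonyl carbon, or a piperidine ring carrying a dimethylamino group there, would help to separate these three changes.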